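Piperidine 4-substituent variation on the shared core

The source may hold more compounds than are shown below. What is called first, only, known or untested is meant among the compounds shown, and "the series" means these compounds.

Compound 1 `CN(C)C(=O)C1CCN(c2nc(-c3cc(F)c(Cl)cc3F)nc3c2CS(=O)(=O)C3)CC1` and compound 2 `O=C(O)C1CCN(c2nc(-c3cc(F)c(Cl)cc3F)nc3c2CS(=O)(=O)C3)CC1` share the same core and differ only in the group on the carbonyl carbon of the piperidine substituent. In a functional assay on HEK293 cells for agonist activity at Glucose-dependent insulinotropic receptor (Homo sapiens), read by reporter gene assay and cAMP accumulation, with a stated time of 6 h (on this read-out higher numbers stand for an effect only at larger amounts of compound and lower numbers for an effect already at smaller amounts), compound 1 gives 350 nM and compound 2 gives 560 nM. Going by the values given here, the step of a 1.6-fold higher number from compound 1 to compound 2 (0.20 log units; within the scatter) is the only measured step so far. Among the compounds with values here, compound 2 has the highest of the two numbers, but its sole neighbour, compound 1, sits within the scatter, so no order between them can be claimed.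

Compound 3 `O=S1(=O)Cc2nc(-c3cc(F)c(Cl)cc3F)nc(N3CCC(O)CC3)c2C1` is not yet measured. Relative to compound 2 the change is hydroxy in place of carboxy on a saturated ring carbon. The measured step of a 1.6-fold higher number from compound 1 to compound 2 (0.20 log units; within the scatter) bears on it only loosely: there the carbonyl remained and only its substituent changed, whereas here the carboxy leaves altogether and a hydroxy stands directly on the ring carbon. Within the data shown here, with one step within the scatter as the only guide, no step beyond the scatter is expected in this assay, in either direction. Compound 3 is therefore estimated at 500 nM, with a range of 180 nM to 1500 nM. The expected step is a 1.1-fold lower number from compound 2 to compound 3 (0.05 log units; within the scatter), with a wide range reflecting the lack of a direct precedent.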

Compound 3, effective concentration (reported as EC, without a stated level of effect): 14 nM
The estimate for compound 3 lay 36-fold (1.55 log units) above the measured number; measured number below the stated range.
By their numbers in this assay, from the lowest: compound 3; then compounds 1 and 2 (each within the scatter of the next).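

In this assay the group on this saturated ring carbon clearly matters: hydroxy in place of carboxy gives a 40-fold lower number from compound 2 to compound 3 (1.60 log units; beyond the scatter), and hydroxy in place of dimethylcarbamoyl gives a 25-fold lower number from compound 1 to compound 3 (1.40 log units; beyond the scatter). The exchange on the carbonyl carbon gave only a 1.6-fold higher number from compound 1 to compound 2 (0.20 log units; within the scatter), so the two carbonyl-bearing groups stay together within the scatter, while the change to 4-hydroxypiperidin-1-yl moves the number well beyond it, and compound 3 has the lowest number of the three, with both of its steps beyond the scatter. No data here explain this difference, so the result stands as an observation only.

The compounds shown leave open whether the hydroxy itself carries these steps or whether losing the carbonyl-bearing group is enough, a question that a methoxy, an amine, a hydroxymethyl or a plain hydrogen on the same ring carbon would help to separate. From the compounds shown here alone, it also remains open whether a step of this size would persist on a core other than the shared core, as all three compounds carry the same one.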